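The source may hold more compounds than are shown below. What is called first, only, known or untested is meant among the compounds shown, and "the series" means these compounds.

Among the compounds with values here, in an in vitro assay on HEK-tsA201 cells for antagonist activity at Neuronal acetylcholine receptor; alpha4/beta2 (Homo sapiens), read by fluorescence and calcium flux (a higher number here means a weaker inhibitor, a lower number a stronger inhibitor), compound 2 `C=CCOc1ccc(C(=O)Nc2cccc(Br)n2)cc1` gives 70100 nM, the higher of the two numbers measured so far. Compound 1 `C=CCOc1ccc(C(=O)Nc2ccccn2)cc1` gives 19300 nM. Within the data shown here, the single measured step runs a 3.6-fold higher number from compound 1 to compound 2 (0.56 log units; beyond the scatter), and it is the only one that bears on the position in question. Compound 3 `C=CCOc1ccc(C(=O)Nc2cccc(CC)n2)cc1` carries ethyl in place of bromo on an aromatic carbon. Among the measured compounds shown here, no measured pair sets ethyl against bromo at this carbon, so the change is expected to leave the number close to that of compound 2; the expected step is a 1.4-fold lower number from compound 2 to compound 3 (0.15 log units; within the scatter). For compound 3 the estimate in this assay is 50000 nM, with a range of 18000 nM to 140000 nM.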

Compound 3, half-maximal inhibitory concentration: 20500 nM
Compound 3: the middle estimate sits 2.4-fold (0.39 log units) above what was measured; measured number inside the range.
By their numbers in this assay, from the lowest: compounds 1 and 3 (each within the scatter of the next); then compound 2.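

In this assay ethyl at this carbon does not carry the rise seen with bromo, with a 3.4-fold lower number from compound 2 to compound 3 (0.53 log units; beyond the scatter), so a group here does not by itself raise the number. Set against hydrogen, ethyl cannot be told apart, with a 1.1-fold higher number from compound 1 to compound 3 (0.03 log units; within the scatter), and of the two groups only bromo stands apart from hydrogen at this carbon. Nothing available explains why bromo and ethyl differ. Open, as far as these compounds go, is whether an amine, a methoxy group or a longer chain at this carbon would follow ethyl or bromo, and whether any group there would give a number clearly lower than that of compound 1.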